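The source may report more compounds than this note shows. Statements on the series, on what has been measured and on what is new or still open speak of the compounds shown alone.

Measured so far in a functional assay on MCF7 cells (Homo sapiens) for antiproliferative activity, read by MTT assay, with a stated time of 72 h; on this read-out higher numbers stand for weaker inhibition and lower numbers for stronger inhibition:

- compound 1 `COc1ncc(-c2ccc3c(c2)N(c2ccccc2)C(=O)CO3)cc1NS(=O)(=O)c1ccc(F)cc1`: 8870 nM
- compound 2 `COc1cccc(N2C(=O)COc3ccc(-c4cccc(NS(=O)(=O)c5ccc(F)cc5)c4)cc32)c1`: > 40000 nM (a limit, not a number)
- compound 3 `O=C1COc2ccc(-c3cnc4ccccc4c3)cc2N1`: > 40000 nM (a limit, not a number)

Only compound 1 has a true number, 8870 nM. Compound 2 stands at the limit of > 40000 nM in this assay, at which 2 of the 3 values shown sit. This means that its real potency is not known, and it gives only a limit to start from, not a fixed point.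

The next compound to be tested is compound 4 `O=C1COc2ccc(-c3cccc(NS(=O)(=O)c4ccc(F)cc4)c3)cc2N1C1CCCCC1`. It differs from compound 2 in one place: cyclohexyl in place of 3-methoxyphenyl on an amide-type nitrogen in a ring. Put simply, cyclohexyl takes the place of 3-methoxyphenyl on an amide-type nitrogen in a ring, while the rest of the molecule stays the same.

Among the measured compounds shown here, no measured pair of compounds shows what this kind of swap does, so any forecast is cautious. The closest guide is compound 2, whose reading in this assay is the limit > 40000 nM. With nothing to suggest a direction, the estimated step of an at least 1.1-fold lower number from compound 2 to compound 4 (0.05 log units; that floor lies within the scatter) is expected to stay within the usual scatter. For compound 4 the expected value is 35000 nM, with an estimated range of 12000 nM to 80000 nM.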

Compound 4, half-maximal inhibitory concentration: 21400 nM
The estimate for compound 4 lay 1.6-fold (0.21 log units) above the measured number; low and high end bracket the measured number.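

In this assay compound 4 gives 21400 nM, a true number, which shows that a non-aromatic ring of carbon only on the amide-type nitrogen in a ring still allows a measurable reading on this core. Compound 2, which carries 3-methoxyphenyl at this position, is known only as a limit: the limit of > 40000 nM in this assay, at which 2 of the 4 values shown sit. Setting cyclohexyl in place of 3-methoxyphenyl gives an at least 1.8-fold lower number from compound 2 to compound 4 (0.27 log units; that floor lies within the scatter), so this change is read only as a floor, and its true size could be small or much larger.

The swap removes an aromatic ring and the methoxy oxygen together, so the compounds shown leave open which of these differences, if either, matters for the reading. They also leave open what happens in the same assay, this assay, when this nitrogen carries a much smaller group such as methyl, or a chain ending in an amine or a carboxylic acid, which would show whether a ring is needed at this position at all.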